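A few compounds are considered here, and "the series" means these few. Any claim that something is new, unique, unknown or untested is made for them only; others in the source may bear on it.

Measured so far:
Compound 1, `CCc1ccccc1N(CC(=O)NCc1ccccc1)S(=O)(=O)c1ccc(C)cc1`, gives 63.1 nM in an assay on CHO cells for displacement of a labelled ligand from prostaglandin E2 receptor EP1 subtype (Homo sapiens); a lower number here means a stronger inhibitor, a higher number a weaker inhibitor.
Compound 2, `CCc1ccccc1N(CC(=O)NCc1cccc(Cl)c1)S(=O)(=O)c1ccc(C)cc1`, gives 251 nM in this assay.
Compound 3, `Cc1ccc(S(=O)(=O)N(CC(=O)NCc2ccc(Cl)cc2)c2ccccn2)cc1`, gives < 1000 nM in this assay; this is a limit of the assay and not a number, the one described as the limit of < 1000 nM in this assay, at which 1 of the 3 values shown sits.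

Compound 3 therefore stands on the numbers only as a limit: where it sits in relation to compound 1 and compound 2 cannot be told from what has been measured. For the measured compounds named here, the single measured step, a 4.0-fold higher number from compound 1 to compound 2 (0.60 log units; beyond the scatter), concerns a chloro group introduced on the benzylic ring and says nothing about a substituent on the pyridine ring.

Compound 4, `Cc1ccc(S(=O)(=O)N(CC(=O)NCc2ccc(Cl)cc2)c2cccc(C)n2)cc1`, differs from compound 3 in methyl in place of hydrogen on an aromatic carbon. Going by the values given here, no measured step bears on this change, so no size or direction of step in this assay can be read from the series; a change of this kind is generally expected to stay within the scatter or to move the number modestly either way. For compound 4 an inhibition constant of 500 nM is expected, with a range from 100 nM to 2500 nM. The step this estimate implies is a step that the limit leaves unreadable from compound 3 to compound 4.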

Compound 4, inhibition constant: < 1000 nM
Compound 4: no number, only a limit; the forecaster's own chance of this, stated with the estimate: 35%; the middle value does not contradict the limit.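

In this assay compound 3 and compound 4 both stand only as limits, so no step between them can be read: the limit of < 1000 nM in this assay, at which 2 of the 4 values shown sit.

The compounds shown leave open whether going from pyridin-2-yl to 6-methylpyridin-2-yl moves the number at all, in which direction, and where these two compounds stand relative to compound 1 and compound 2.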